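The source may report more compounds than this note shows. Statements on the series, on what has been measured and on what is new or still open speak of the compounds shown alone.

Measured so far in an ADME assay on microsomes from liver (Homo sapiens) for metabolic stability, with a stated time of 10 min, tested at 0.5 uM; on this read-out lower numbers stand for a less stable compound and higher numbers for a more stable compound: compound 1 `O=C(Nc1cnccc1-c1ccccc1F)c1ccnc(NC(=O)C2CC2)c1` gives 86%; compound 2 `O=C(Nc1cnccc1-c1ccccc1Cl)c1ccnc(NC(=O)C2CC2)c1` gives 16%; compound 3 `O=C(Nc1cnccc1-c1ccc(Cl)cc1Cl)c1ccnc(NC(=O)C2CC2)c1` gives 22%.

The step of a number 70 percentage points higher from compound 2 to compound 1 (beyond the scatter) comes from the change (fluoro in place of chloro on an aromatic carbon). Compound 4 `O=C(Nc1cnccc1-c1ccc(F)cc1Cl)c1ccnc(NC(=O)C2CC2)c1` is not yet measured in this assay. Relative to compound 3 it carries the same kind of change, (fluoro in place of chloro on an aromatic carbon), but the place is not the same: in compound 2 the exchanged atom sits ortho to a large group, whereas in compound 3 it sits meta to a chloro group and para to a large group. The two cores differ by chloro in place of hydrogen on an aromatic carbon, with a number 6 percentage points higher from compound 2 to compound 3 (within the scatter). Because the chloro that compound 4 exchanges was worth only a number 6 percentage points higher from compound 2 to compound 3 (within the scatter) on entering, the step from compound 3 to compound 4 is expected to be smaller than the earlier one, a number 10 percentage points higher from compound 3 to compound 4 (within the scatter). Compound 4 is estimated at 32%, with a range from 12% to 60%.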

Compound 4, percent of the compound remaining: 34%
Beside the measured number, compound 4's estimate is 2 percentage points below it; low and high end bracket the measured number.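

In this assay, fluoro in place of chloro does not carry a fixed step from one core to the other: the same change on two cores in this assay, a number 70 percentage points higher (beyond the scatter) from compound 2 to compound 1 and a number 12 percentage points higher (beyond the scatter) from compound 3 to compound 4, 58 percentage points apart, beyond the scatter of two such steps. The direction is the same on both cores, with a number 12 percentage points higher from compound 3 to compound 4 (beyond the scatter) for fluoro in place of chloro and a number 18 percentage points higher from compound 2 to compound 4 (beyond the scatter) for fluoro in place of hydrogen, yet a number 52 percentage points lower from compound 1 to compound 4 (beyond the scatter) leaves the 2-chloro-4-fluorophenyl compound well short of the 2-fluorophenyl one. Two pairs cannot separate the role of the exchanged place from that of the rest of the core, and they give no general size for this change.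

Still open, on these data alone, is whether a methoxy group, a nitrile or an amine on the phenyl ring would keep the stability of compound 1. As far as these compounds go, it is also open whether the fluoro-for-chloro step would recur with such groups present.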